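Nitro to Trifluoromethyl on Two Related Cores

A few compounds are considered here, and "the series" means these few. Any claim that something is new, unique, unknown or untested is made for them only; others in the source may bear on it.

Compound 1 `CC(C)=CCC/C(C)=C/CC/C(C)=C/CC[C@@H]1[C@@]2(C)CC/C(=N\OCc3cn(-c4cccc([N+](=O)[O-])c4)nn3)C(C)(C)[C@@H]2CC[C@@]1(C)O` carries a nitro group on the aryl ring attached to its triazole. In a functional assay on HeLa cells (Homo sapiens) for cytotoxicity, read by MTT assay, with a stated time of 48 h (on this read-out lower numbers stand for stronger inhibition and higher numbers for weaker inhibition), compound 1 gives 18400 nM. Compound 2 `CC(C)=CCC/C(C)=C/CC/C(C)=C/CC[C@@H]1[C@@]2(C)CC/C(=N\OCc3cn(-c4cccc(C(F)(F)F)c4)nn3)C(C)(C)[C@@H]2CC[C@@]1(C)O` differs from it in one place: trifluoromethyl in place of nitro on an aromatic carbon. This change produced a 1.5-fold lower number from compound 1 to compound 2 (0.17 log units; within the scatter), so in this assay compound 2 gives 12500 nM, a number that cannot be told apart from that of compound 1.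

Compound 3 `CC(C)=CCC/C(C)=C/CC/C(C)=C/CC[C@@H]1[C@@]2(C)C/C(=C\c3ccc(OCc4cn(-c5cccc([N+](=O)[O-])c5)nn4)cc3)C(=O)C(C)(C)[C@@H]2CC[C@@]1(C)O` keeps the nitro-bearing aryl triazole but sits on a different core; the difference between the two cores is not broken down here. In this assay compound 3 gives 32900 nM. Against compound 1 this number lies within the scatter, while against compound 2 it lies beyond it, compound 2 having the lower number of the two.

Compound 4 `CC(C)=CCC/C(C)=C/CC/C(C)=C/CC[C@@H]1[C@@]2(C)C/C(=C\c3ccc(OCc4cn(-c5cccc(C(F)(F)F)c5)nn4)cc3)C(=O)C(C)(C)[C@@H]2CC[C@@]1(C)O` has not yet been measured. It stands to compound 3 as compound 2 stands to compound 1: trifluoromethyl in place of nitro on an aromatic carbon. The two places read the same word for word, so this is the same change made on a second core. Because the earlier change gave only a 1.5-fold lower number from compound 1 to compound 2 (0.17 log units; within the scatter), a step of similar size is expected here, estimated as a 1.5-fold lower number from compound 3 to compound 4 (0.17 log units; within the scatter). On that basis compound 4 is expected to give about 22000 nM in this assay, with a range from 10000 nM to 45000 nM.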

Compound 4, half-maximal inhibitory concentration: 17300 nM
Estimate against measurement, compound 4: 1.3-fold (0.10 log units) above, and the stated range covers the measured number.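

On the second core, trifluoromethyl in place of nitro gave a 1.9-fold lower number from compound 3 to compound 4 (0.28 log units; within the scatter) in this assay, so the two numbers cannot be told apart. Set beside the same change on the first core, this step shows that the swap from 3-nitrophenyl to 3-(trifluoromethyl)phenyl reads alike on both cores, with no difference that can be resolved between the two steps: the same change on two cores in this assay, a 1.5-fold lower number (0.17 log units; within the scatter) from compound 1 to compound 2 and a 1.9-fold lower number (0.28 log units; within the scatter) from compound 3 to compound 4, 1.3-fold (0.11 log units) apart, within the scatter of two such steps. It does not show that trifluoromethyl is better than nitro on either core, since neither step rises above the scatter, and agreement between two small steps on two cores cannot establish that the change would behave the same way on any other core in this series.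

The compounds shown leave open what other groups would give at this same place on the aromatic ring, such as a nitrile, an amine or a carboxylic acid, and whether any of them would produce a step large enough to be read in this assay. They also leave open how much the two cores themselves contribute, as compounds on different cores differ in more than one place.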